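The source may report more compounds than this note shows. Statements on the series, on what has been measured and on what is new or still open speak of the compounds shown alone.

In a functional assay on brain (Rattus norvegicus, strain Wistar) for inhibition (a lower number here means a stronger inhibitor, a higher number a weaker inhibitor), three compounds with a shared core have been measured. Compound 1 `CCCCOc1ccc(-c2c(C)[nH]c(=O)n2C2CCCCC2)cc1` gives 13900 nM in this test, compound 2 `CCCCCc1ccc(-c2c(C)[nH]c(=O)n2C2CCCCC2)cc1` gives 10600 nM and compound 3 `CCCCCCc1ccc(-c2c(C)[nH]c(=O)n2C2CCCCC2)cc1` gives 13700 nM as its half-maximal inhibitory concentration. Compound 3 thus stands among values that cannot be told apart. The steps of a 1.0-fold lower number from compound 1 to compound 3 (0.01 log units; within the scatter) and a 1.3-fold higher number from compound 2 to compound 3 (0.11 log units; within the scatter) stay within the scatter, as does the step of a 1.3-fold lower number from compound 1 to compound 2 (0.12 log units; within the scatter) in this small set. Compound 4 `CCCCCCCc1ccc(-c2c(C)[nH]c(=O)n2C2CCCCC2)cc1` carries one change against compound 3: methyl in place of hydrogen on a saturated chain carbon, six bonds along the chain from an aromatic carbon in the chain. The nearest parallel, methyl in place of hydrogen five bonds along the chain, is the step of a 1.3-fold higher number from compound 2 to compound 3 (0.11 log units; within the scatter) and it stayed within the scatter. In this assay the expected step is therefore a 1.1-fold lower number from compound 3 to compound 4 (0.02 log units; within the scatter) and nothing beyond the scatter. For compound 4 the estimated value is 13000 nM with an expected range from 7000 nM to 25000 nM in this measurement.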

Compound 4, half-maximal inhibitory concentration: 8700 nM
Beside the measured number, compound 4's estimate is 1.5-fold (0.17 log units) above it, and the stated range covers the measured number.
By their numbers in this assay, from the lowest: compounds 4, 2, 3 and 1 (each within the scatter of the next).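

Methyl in place of hydrogen six bonds along the chain gives a 1.6-fold lower number from compound 3 to compound 4 (0.20 log units; within the scatter) in this assay and so, at this position further out on the chain, the added carbon again produces no step beyond the scatter. The wider changes agree: ethyl in place of hydrogen five bonds along the chain gives a 1.2-fold lower number from compound 2 to compound 4 (0.09 log units; within the scatter) and heptyl in place of butoxy gives a 1.6-fold lower number from compound 1 to compound 4 (0.20 log units; within the scatter) so all four compounds remain indistinguishable. Nothing available explains this flat picture.

On these data alone, whether a longer chain such as octyl, or an amine at the chain end, would move the number beyond the scatter stays open.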